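Replacing a benzyloxy arm in a weak bile acid receptor ligand

The source may report more compounds than this note shows. Statements on the series, on what has been measured and on what is new or still open speak of the compounds shown alone.

Compound 1, `COC(=O)/C=C/c1cccc(N(Cc2ccc(-c3ccc(SC)cc3)cc2)C(=O)C(C)C)c1`: 51 nM
Compound 2, `COC/C=C/c1ccc(CN(C(=O)C2CCCCC2)c2cccc(/C=C/C(=O)OC)c2)cc1`: 233 nM
Compound 3, `COC(=O)/C=C/c1cccc(N(Cc2ccc(/C=C/C(=O)OC(C)(C)C)cc2OCc2ccccc2)C(=O)C2CCCCC2)c1`: > 1000 nM

Of the compounds shown here, three have been measured in an assay on isolated protein with Bile acid receptor (Homo sapiens) as the target; on this read-out higher numbers stand for an effect only at larger amounts of compound and lower numbers for an effect already at smaller amounts. Compound 1 gives 51 nM and compound 2 gives 233 nM. Compound 3 sits at the limit of > 1000 nM in this assay, at which 1 of the 3 values shown sits, which is a limit of the assay and not a number, so compound 3 is the only one of the three without a fixed value and stands at the weak end of what is shown.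

Compound 4, `CCOC(=O)COc1cc(/C=C/C(=O)OC(C)(C)C)ccc1CN(C(=O)C1CCCCC1)c1cccc(/C=C/C(=O)OC)c1`, is the next compound to be measured in this assay. It differs from compound 3 in one place: ethoxycarbonyl in place of phenyl on a saturated chain carbon bound to an oxygen on an aromatic ring, so that the benzyloxy group becomes (ethoxycarbonyl)methoxy. Among the compounds with values here, no pair of measured compounds shows this change, so its effect on this assay cannot be read from a measured step. Since compound 3 is known only as a limit, the step that the limit leaves unreadable from compound 3 to compound 4 is expected to be modest and of uncertain direction, with the chance that compound 4 also lands at a limit. Compound 4 is expected to give about 1200 nM, within the range 300 nM to 5000 nM.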

Compound 4, half-maximal effective concentration: > 1000 nM
Compound 4 was reported as a limit; the forecaster's own chance of this, stated with the estimate: 45%; the middle value lies beyond the limit too.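

In this assay compound 4 gives > 1000 nM, which is a limit and not a number. Compound 3 gives > 1000 nM, also a limit, so no step can be read between compound 3 and compound 4: the limit of > 1000 nM in this assay, at which 2 of the 4 values shown sit. The compounds shown leave open whether ethoxycarbonyl in place of phenyl on that saturated chain carbon changes the value in this assay at all, and in which direction.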